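The compounds below may be only part of what the source reports. "The series", "measured", "known", "first", "only" and "open" are said of these compounds alone.

In a study of cytotoxicity, compound 3 `COC(=O)CCn1c(=O)c(-c2ccc(OC)cc2)cc2c(OC)cc(OC)cc21` is measured in a functional assay on A549 cells (Homo sapiens) for cytotoxicity, read by colorimetric assay and MTT assay (on this read-out higher numbers stand for weaker inhibition and lower numbers for stronger inhibition), where compound 3 gives 10000 nM. Compound 3 is level with compound 1 `COc1ccc(-c2cc3c(OC)cc(OC)cc3n(CC#N)c2=O)cc1`, which in this assay gives 10000 nM, and with compound 2 `COc1ccc(-c2cc3c(OC)cc(OC)cc3n(CC(=O)OCc3ccccc3)c2=O)cc1`, which in this assay gives 10000 nM. The measured steps are all flat: no change at the digits printed from compound 1 to compound 2 (within the scatter), no change at the digits printed from compound 1 to compound 3 (within the scatter) and no change at the digits printed from compound 2 to compound 3 (within the scatter). Each of these exchanges one group on a saturated chain carbon bound to an aromatic nitrogen, and none moves the read-out beyond the scatter.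

Compound 4 `CCN(CC)C(=O)CCn1c(=O)c(-c2ccc(OC)cc2)cc2c(OC)cc(OC)cc21` differs from compound 3 in one place: diethylamino in place of methoxy on a carbonyl carbon. Among the measured compounds shown here, no measured step alters a carbonyl carbon in this way, so the three flat steps are the only guide, and they bear on it only loosely, as changes along the same chain. On that basis the account expects no step beyond the scatter, no change at the digits printed from compound 3 to compound 4 (within the scatter). Compound 4 is therefore estimated at 10000 nM, with a range from 5000 nM to 20000 nM.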

Compound 4, half-maximal inhibitory concentration: 10000 nM
Compound 4: middle estimate and measured number agree at the digits printed, within the range that was stated.
By their numbers in this assay, from the lowest: compounds 1, 2, 3 and 4 (each within the scatter of the next).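

In this assay the exchange made on the carbonyl carbon itself, diethylamino in place of methoxy, gives no change at the digits printed from compound 3 to compound 4 (within the scatter) and so proves as flat as the exchanges on the saturated chain carbon bound to the aromatic nitrogen. The 2-(diethylcarbamoyl)ethyl chain also shows no change at the digits printed from compound 2 to compound 4 (within the scatter) and no change at the digits printed from compound 1 to compound 4 (within the scatter), which places a chain ending in a diethylcarbamoyl group level with those ending in nitrile, benzyloxycarbonyl and methoxycarbonyl. No measurement here explains why these read-outs stay level.

On these data alone, whether a primary amine or a carboxylic acid at the end of this chain would shift the read-out stays open. So does whether a longer chain or a hydroxyl group in place of the methoxy on the core would do so.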